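Alpha-ketooxazole series: truncating the chain end

This account rests on a few compounds, and the source may have more. Where it says the series, first, only, none or still open, it means among the compounds named here.

Measured so far, in an assay for inhibition of Fatty-acid amide hydrolase 1 (Rattus norvegicus); on this read-out lower numbers stand for stronger inhibition and higher numbers for weaker inhibition:
compound 1 `O=C(CCCCC#Cc1ccccn1)c1ncc(-c2ccccn2)o1` gives 280 nM
compound 2 `O=C(CCCCC#Cc1cccc(F)c1)c1ncc(-c2ccccn2)o1` gives 3.2 nM

Compound 1 stands highest of the two numbers in this assay; its nearest neighbour is compound 2, reached by the step of an 88-fold lower number from compound 1 to compound 2 (1.94 log units; beyond the scatter) through a 3-fluorophenyl in place of pyridin-2-yl on a triple-bonded carbon. That single step shows how strongly the group at the chain end moves the read-out within this core.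

Compound 3 `COC(=O)CCCCC(=O)c1ncc(-c2ccccn2)o1` is not yet measured. It differs from compound 1 by methoxycarbonyl in place of 2-(pyridin-2-yl)ethynyl on a saturated chain carbon, four bonds along the chain from a carbonyl carbon. For the measured compounds named here, no measured step removes the ring and the triple bond from this position, so the one step measured bears only indirectly: it shows the chain end matters, not what a methoxycarbonyl does there. Going by the values given here, with the large step from compound 1 to compound 2 as the only guide, a step beyond the scatter is expected, towards a higher number. Compound 3 is therefore estimated at 3000 nM, in the range 700 nM to 15000 nM, a step of an 11-fold higher number from compound 1 to compound 3 (1.03 log units; beyond the scatter).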

Compound 3, inhibition constant: 1800 nM
Beside the measured number, compound 3's estimate is 1.7-fold (0.22 log units) above it; low and high end bracket the measured number.
By their numbers in this assay, from the lowest: compound 2; then compound 1; then compound 3.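

In this assay, replacing 2-(pyridin-2-yl)ethynyl with methoxycarbonyl gives a 6.4-fold higher number from compound 1 to compound 3 (0.81 log units; beyond the scatter), a modest step even though the ring and the triple bond both leave the chain end. The earlier pair changed only the ring on the triple-bonded carbon, whereas compound 3 shows that a finite number in this assay does not require either a ring or a triple bond at this position. The data shown offer no measurement that accounts for this step.

The step combines the loss of the ring, the loss of the triple bond and the entry of methoxycarbonyl, so their separate contributions cannot be read. As far as these compounds go, how a carboxylic acid, a primary amide or a longer chain ending in methoxycarbonyl would move the number at this position remains open.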